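Moving a Methoxycarbonyl Pyridine Around the Shared Core

The compounds below may be only part of what the source reports. "The series", "measured", "known", "first", "only" and "open" are said of these compounds alone.

In an assay for inhibition of Fatty-acid amide hydrolase 1 (Rattus norvegicus) (a lower number here means a stronger inhibitor, a higher number a weaker inhibitor), compound 2 `COC(=O)c1ccc(-c2cnc(C(=O)CCc3ccc(-c4ccccc4)cc3)o2)nc1` gives 2.2 nM, the lowest of the two numbers recorded so far. Compound 1 `CCOC(=O)c1cccc(-c2cnc(C(=O)CCc3ccc(-c4ccccc4)cc3)o2)n1` gives 3 nM, and the two values lie within the scatter of each other. Compound 3 `COC(=O)c1cc(-c2cnc(C(=O)CCc3ccc(-c4ccccc4)cc3)o2)ccn1` has not yet been measured. It differs from compound 2 in one place: 2-(methoxycarbonyl)pyridin-4-yl in place of 5-(methoxycarbonyl)pyridin-2-yl on an aromatic carbon. Among the compounds with values here, no measured pair shows the effect of such a rearrangement of the same atoms. A small weakening, or no change beyond the scatter, is expected for a 2.3-fold higher number from compound 2 to compound 3 (0.36 log units; beyond the scatter). Compound 3 is therefore estimated at 5 nM, with a range from 1.5 nM to 20 nM.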

Compound 3, inhibition constant: 1.5 nM
Compound 3: middle estimate off by 3.3-fold (0.52 log units), on the high side, within the range that was stated.
By their numbers in this assay, from the lowest: compounds 3, 2 and 1 (each within the scatter of the next).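

In this assay the exchange of 5-(methoxycarbonyl)pyridin-2-yl for 2-(methoxycarbonyl)pyridin-4-yl, on the aromatic carbon next to the ring oxygen, gives a 1.5-fold lower number from compound 2 to compound 3 (0.17 log units; within the scatter) and so leaves the two compounds indistinguishable. This first measured pair shows that this rearrangement of the same atoms, at this position on the shared core, produces no change beyond the scatter. No measurement at hand gives a reason for this outcome.

Open, going by these compounds, is whether a carboxylic acid or an amide in place of the methyl ester would behave the same way on either pyridine. Also open, on these data alone, is whether an unsubstituted pyridine would do so at this position.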